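Swapping an aryl ketone in a cytotoxicity screen

This account rests on a few compounds, and the source may have more. Where it says the series, first, only, none or still open, it means among the compounds named here.

The compounds share one core, carrying a carbonyl on a double-bonded chain carbon. Compound 1 (`Cc1ccccc1C(=O)/C=C1\Nc2ccccc2OC1=O`) was tested in an ADME assay on Vero cells (Chlorocebus sabaeus) for cytotoxicity, read by MTT assay, with a stated time of 72 h; a lower number here means that less compound is tolerated, a higher number that more compound is tolerated. For compound 1 the result is a limit of the assay rather than a number, > 1790000 nM. Compound 2 (`COC(=O)/C=C1\Nc2cc(Cl)ccc2OC1=O`) carries a methyl ester and a chlorine on the core instead, and in this assay compound 2 gives 1630000 nM. Where compound 1 stands can be said only to this extent: its result sits at the limit, (the limit of > 1790000 nM in this assay, at which 1 of the 2 values shown sits), and the two values shown both lie at the top of the measured range, within the usual scatter of each other. Compound 3 (`O=C1Oc2ccccc2N/C1=C\C(=O)c1cccc(Cl)c1`) differs from compound 1 in one place: 3-chlorophenyl in place of 2-methylphenyl on a carbonyl carbon. No measured step connects two of these compounds, so the size of the change cannot be read from a pair. The author expects a step from compound 1 to compound 3 of no more than the usual scatter, with no direction called, an at least 1.0-fold lower number from compound 1 to compound 3 (0.02 log units; that floor lies within the scatter). Compound 3 is therefore estimated at 1700000 nM in this assay, with a range from 800000 nM to 1790000 nM, and most likely again reported as a limit.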

Compound 3, half-maximal cytotoxic concentration: 1610000 nM
Estimate against measurement, compound 3: 1.1-fold (0.02 log units) above, within the range that was stated.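

Going by these compounds alone, the exchange gives the first step that can be read at this position: on a carbonyl carbon whose other neighbour is the double-bonded chain carbon, 3-chlorophenyl in place of 2-methylphenyl gives an at least 1.1-fold lower number from compound 1 to compound 3 (0.04 log units; that floor lies within the scatter) in this assay. That step is a floor and not a full size, because compound 1 stands at a limit: the limit of > 1790000 nM in this assay, at which 1 of the 3 values shown sits. Compound 1 and compound 2 differ in more than one place and could say nothing about this position alone, whereas this single pair shows that one aryl group can stand in for the other here without the number moving beyond the usual scatter.

The compounds shown leave open whether an amine or a carboxylic acid on this carbonyl carbon, or a longer chain in place of the aryl ring, would keep the number in the same range in this assay. Within the data shown here, no pair here isolates the chlorine on the core of compound 2 or its methyl ester, so the contribution of each to that compound's value remains unread.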